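Replacing 2,5-dimethylphenyl with isoquinolin-4-yl: what to expect

The compounds below may be only part of what the source reports. "The series", "measured", "known", "first", "only" and "open" are said of these compounds alone.

Compound 1 `CC1(C)CCC[C@]2(C)[C@@H](CC[C@@](C)(O)/C=C/c3ccccc3)[C@](C)(O)CC[C@@H]12`: 3150 nM
Compound 2 `Cc1ccc(C)c(/C=C/[C@](C)(O)CC[C@@H]2[C@@]3(C)CCCC(C)(C)[C@@H]3CC[C@@]2(C)O)c1`: 3320 nM

These two compounds were tested in a functional assay on A549 cells (Homo sapiens) for cytotoxicity, read by MTT assay, with a stated time of 48 h; a higher number here means a weaker inhibitor, a lower number a stronger inhibitor. Among the compounds with values here, compound 2 has only one measured neighbour, compound 1, and their two values lie within the usual scatter of each other.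

The unmeasured compound 3 `CC1(C)CCC[C@]2(C)[C@@H](CC[C@@](C)(O)/C=C/c3cncc4ccccc34)[C@](C)(O)CC[C@@H]12` keeps the shared core and changes one group: isoquinolin-4-yl in place of 2,5-dimethylphenyl on a double-bonded chain carbon bound to a double-bonded chain carbon. In words, isoquinolin-4-yl stands in place of 2,5-dimethylphenyl on a double-bonded chain carbon bound to a double-bonded chain carbon.

Within the data shown here, only one measured step bears on this change, a swap at the same place: a 1.1-fold higher number from compound 1 to compound 2 (0.02 log units; within the scatter). That step is small, but it is a single step. Among the measured compounds shown here, no measured compound here carries a ring with a hetero atom or a second aromatic ring on the chain, so the evidence is thin. The starting point therefore remains compound 2 at 3320 nM, and no shift beyond the scatter is expected in this assay.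

The expected size of the change is a 1.1-fold lower number from compound 2 to compound 3 (0.04 log units; within the scatter). For compound 3 the estimated value is 3000 nM, with an expected range of 1200 nM to 7500 nM.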

Compound 3, half-maximal inhibitory concentration: 45700 nM
Estimate against measurement, compound 3: 15-fold (1.18 log units) below; the whole stated range lies below it.
By their numbers in this assay, from the lowest: compounds 1 and 2 (each within the scatter of the next); then compound 3.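

In this assay this place on the chain proves sensitive to what it carries: isoquinolin-4-yl in place of 2,5-dimethylphenyl gives a 14-fold higher number from compound 2 to compound 3 (1.14 log units; beyond the scatter) and isoquinolin-4-yl in place of phenyl gives a 15-fold higher number from compound 1 to compound 3 (1.16 log units; beyond the scatter) and so both steps point to a much weaker compound. The earlier pair showed only that phenyl and 2,5-dimethylphenyl give values within the scatter of each other, and compound 3 now shows that this tolerance does not reach every aromatic group placed here. The new group differs from the old ones in two ways at once, since it brings a second six-membered aromatic ring and also a ring nitrogen, and the loss belongs to that combined change.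

The compounds shown leave open which of the two matters, and a naphthalen-1-yl group, with the second ring but no nitrogen, together with a pyridin-3-yl group, with the nitrogen but no second ring, would pull them apart. Nothing measured here accounts for the loss seen with compound 3.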